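Fluoro in Place of Nitro: an Expected Cytotoxicity Shift

A few compounds are considered here, and "the series" means these few. Any claim that something is new, unique, unknown or untested is made for them only; others in the source may bear on it.

Two ureas were examined in a functional assay on Daoy cells (Homo sapiens) for cytotoxicity, read by MTT assay, with a stated time of 72 h; on this read-out lower numbers stand for stronger inhibition and higher numbers for weaker inhibition. Compound 1 `COc1cc(N(C)C(=O)N(C)c2ccc([N+](=O)[O-])cc2)cc(OC)c1OC` is reported there only as a limit, >= 125000 nM, and so it stands at the limit of >= 125000 nM in this assay, at which 1 of the 2 values shown sits, rather than at a measured number. Compound 2 `COc1ccc(NC(=O)Nc2cc(OC)c(OC)c(OC)c2)cc1` gives 14900 nM in this assay. Among the compounds with values here, no step between these two is computed, and their values show no more than that one is a limit and the other a number.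

Compound 3 `COc1cc(N(C)C(=O)N(C)c2ccc(F)cc2)cc(OC)c1OC` has not yet been measured. It differs from compound 1 by fluoro in place of nitro on an aromatic carbon. Within the data shown here, because compound 1 sits at the limit of >= 125000 nM in this assay, at which 1 of the 2 values shown sits, the size of the change cannot be anchored to a number, and no other pair here carries the same change. The step of an at least 2.0-fold lower number from compound 1 to compound 3 (0.31 log units; beyond the scatter) is expected to be modest, toward stronger inhibition, but compound 3 is still expected to be a weak inhibitor. Compound 3 is estimated at 60000 nM, within 15000 nM to 200000 nM.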

Compound 3, half-maximal inhibitory concentration: >= 125000 nM
Compound 3 ended at the assay's limit (the forecaster's own chance of this, stated with the estimate: 45%); middle value at least 2.0-fold (0.31 log units) from the limit.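

No step from compound 1 to compound 3 can be read in this assay, because the two compounds share one limit rather than measured numbers: the limit of >= 125000 nM in this assay, at which 2 of the 3 values shown sit.

The compounds shown leave open whether fluoro in place of nitro on an aromatic carbon changes cytotoxicity at all, and by how much.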